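Butyl extension on a diastereomeric amino-ether core

This account rests on a few compounds, and the source may have more. Where it says the series, first, only, none or still open, it means among the compounds named here.

Compound 1, `CCCCCCCNC[C@@H]1OC[C@H](N)[C@@H]1O`, gives 22400 nM in a functional assay on PC-3 cells (Homo sapiens) for antiproliferative activity, read by MTT assay, with a stated time of 72 h; on this read-out higher numbers stand for weaker inhibition and lower numbers for stronger inhibition.
Compound 2, `CCCCCCCCCCCNC[C@@H]1OC[C@H](N)[C@@H]1O`, gives 3330 nM in this assay.
Compound 3, `CCCCCCCNC[C@@H]1OC[C@H](N)[C@H]1O`, is reported in this assay only as a limit, > 128000 nM.

Two changes are covered by the measured pairs. The first is butyl in place of hydrogen on a saturated chain carbon, seven bonds along the chain from an amine nitrogen, which produced a 6.7-fold lower number from compound 1 to compound 2 (0.83 log units; beyond the scatter). The second is the two compounds have the same atoms and bonds and differ only in configuration as drawn: 1 of 3 stereo elements differ; a stereocentre at a saturated ring carbon is drawn S in compound 1 and R in compound 3, which produced an at least 5.7-fold higher number from compound 1 to compound 3 (0.75 log units; beyond the scatter); for compound 3 the assay gives only a boundary, (the limit of > 128000 nM in this assay, at which 1 of the 3 values shown sits), so the true size of that step is open, and the two cores differ only as stated in the fact that compounds 1 and 3 differ only in the configuration as drawn.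

Compound 4, `CCCCCCCCCCCNC[C@@H]1OC[C@H](N)[C@H]1O`, has not been measured. It differs from compound 3 by butyl in place of hydrogen on a saturated chain carbon, seven bonds along the chain from an amine nitrogen, the same change as from compound 1 to compound 2, made on the core of compound 3 rather than the core of compound 1; the two place descriptions agree word for word.

In this assay compound 4 is expected to sit lower than compound 3, by a step estimated at an at least 2.1-fold lower number from compound 3 to compound 4 (0.32 log units; beyond the scatter), resting on the single measured occurrence of this change, a 6.7-fold lower number from compound 1 to compound 2 (0.83 log units; beyond the scatter). Because compound 3 is known only through > 128000 nM, the starting point is uncertain, and compound 4 may itself fall at the limit. The estimate for compound 4 is 60000 nM, with a range from 15000 nM to 250000 nM.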

Compound 4, half-maximal inhibitory concentration: 10000 nM
Beside the measured number, compound 4's estimate is 6.0-fold (0.78 log units) above it; the measured number lies below the stated range.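

In this assay the butyl change lowers the number on both cores, so its direction carries over from the core of compound 1 to the core of compound 3, and the new occurrence is an at least 12-fold lower number from compound 3 to compound 4 (1.10 log units; beyond the scatter), which sets the two side by side as follows: the same change on two cores in this assay, a 6.7-fold lower number (0.83 log units; beyond the scatter) from compound 1 to compound 2 and an at least 12-fold lower number (1.10 log units; beyond the scatter) from compound 3 to compound 4; the limit leaves it open whether they differ. This does not show that the size of the change carries over, nor does one occurrence on each of two cores make a general rule, and the open point lies in the reading for compound 3, which is a limit and not a number: the limit of > 128000 nM in this assay, at which 1 of the 4 values shown sits. The core still matters once the butyl is in place, with a 3.0-fold higher number from compound 2 to compound 4 (0.48 log units; beyond the scatter), the same direction as on the shorter chain, and this step can be read as a change of configuration alone: the fact that compounds 2 and 4 differ only in the configuration as drawn.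

The compounds shown leave open whether a longer chain would lower the number further on either core, and whether a phenyl group at the end of the chain would act as butyl does. They also leave open what the other two stereo elements contribute, since only one of the three differs between the compared cores.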